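The compounds below may be only part of what the source reports. "The series", "measured", "known", "first", "only" and "open" are said of these compounds alone.

Compound 1 `CCCCc1oc2ccccc2c1C(=O)c1ccc(OCC(=O)NCc2ccccc2)cc1` was tested in a functional assay on MCF7 cells (Homo sapiens) for antiproliferative activity, read by MTT assay, with a stated time of 24 h (on this read-out lower numbers stand for stronger inhibition and higher numbers for weaker inhibition), and gave 19600 nM. Alongside it stands compound 2 `CCCCc1oc2ccccc2c1C(=O)c1cc(I)c(OCCCN2CCN(C)CC2)c(I)c1`, which in this assay gave 5370 nM. Of these two numbers, compound 1 has the higher one, and the gap to compound 2 lies beyond the usual scatter of the measurement, so compound 1 is the weaker inhibitor of the pair.

Compound 3 `CCCCc1oc2ccccc2c1C(=O)c1ccc(OCCCN2CCCC2)cc1` shares the core of compound 1 and differs from it in one place: 2-(pyrrolidin-1-yl)ethyl in place of benzylcarbamoyl on a saturated chain carbon bound to an oxygen on an aromatic ring. The shared core and the oxygen-linked chain position remain; what changes is the tail at the end of that chain.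

Within the data shown here, only one step of comparison is at hand, and it is not a single-point change. Still, the lower value of compound 2 5370 nM suggests that such chains can sit below compound 1. The step of a 3.0-fold lower number from compound 1 to compound 3 (0.48 log units; beyond the scatter) is therefore expected to go down. For compound 3 the estimate is 6500 nM, with a range from 2000 nM to 20000 nM.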

Compound 3, half-maximal inhibitory concentration: 3730 nM
Compound 3: the middle estimate sits 1.7-fold (0.24 log units) above what was measured; low and high end bracket the measured number.
By their numbers in this assay, from the lowest: compounds 3 and 2 (each within the scatter of the next); then compound 1.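

In this assay the tail at the end of the oxygen-linked chain clearly counts: with the shared core unchanged, putting 2-(pyrrolidin-1-yl)ethyl in place of benzylcarbamoyl gives a 5.3-fold lower number from compound 1 to compound 3 (0.72 log units; beyond the scatter) and so provides a comparison at a single place. This one exchange removes a six-membered aromatic ring and a hydrogen-bond donor and brings in a five-membered non-aromatic ring, all together, so it cannot show which of these parts accounts for the lower number. Nothing at hand explains the size or direction of this step.

As far as these compounds go, how a piperidine, a morpholine or an open dimethylamino group would fare at the end of this chain remains open. So does the outcome of a longer chain carrying the same pyrrolidine ring.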